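Inverting the ring stereocentre of the tetradecyl amide

A few compounds are considered here, and "the series" means these few. Any claim that something is new, unique, unknown or untested is made for them only; others in the source may bear on it.

In a functional assay on cells (Homo sapiens) for antiproliferative activity, read by sulforhodamine B assay, with a stated time of 48 h (on this read-out higher numbers stand for weaker inhibition and lower numbers for stronger inhibition), compound 1 (`CCCCCCCCNC(=O)[C@@H]1CSC(c2cc(OC)c(OC)c(OC)c2)N1`) gives 17100 nM, compound 2 (`CCCCCCCCCCCCCCNC(=O)[C@@H]1CSC(c2cc(OC)c(OC)c(OC)c2)N1`) gives 2000 nM and compound 3 (`CCCCCCCCCCCCCCCCNC(=O)[C@@H]1CSC(c2cc(OC)c(OC)c(OC)c2)N1`) gives 1800 nM. Compound 2 therefore stands level with compound 3 and well under compound 1: the steps are an 8.6-fold lower number from compound 1 to compound 2 (0.93 log units; beyond the scatter), a 9.5-fold lower number from compound 1 to compound 3 (0.98 log units; beyond the scatter) and a 1.1-fold lower number from compound 2 to compound 3 (0.05 log units; within the scatter).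

Compound 4 (`CCCCCCCCCCCCCCNC(=O)[C@H]1CSC(c2cc(OC)c(OC)c(OC)c2)N1`) keeps the chain of compound 2 and changes only its configuration: the two compounds have the same atoms and bonds; at least one stereo element is drawn with a configuration in one of them and without one in the other: 1 of 2 stereo elements differ; a stereocentre at a saturated ring carbon is drawn R in compound 2 and S in compound 4. All three measured steps lengthen the chain, and none alters a stereocentre, so they bear on this change only indirectly. They show the spread of the series, not the size of an inversion. Among the compounds with values here, no measured pair tests the ring stereocentre, so no shift beyond the scatter is expected in this assay, and the range is kept wide. The estimated step is a 1.3-fold higher number from compound 2 to compound 4 (0.10 log units; within the scatter). For compound 4 the expected value is 2500 nM, with an estimated range of 900 nM to 7000 nM.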

Compound 4, half-maximal inhibitory concentration: 2600 nM
For compound 4 the middle estimate is 1.0-fold (0.02 log units) below the measured one; the measured number falls inside the stated range.
By their numbers in this assay, from the lowest: compounds 3, 2 and 4 (each within the scatter of the next); then compound 1.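

In this assay the ring stereocentre is now tested directly, and the inversion gives a 1.3-fold higher number from compound 2 to compound 4 (0.11 log units; within the scatter). For the tetradecyl amide, a ring carbon drawn S rather than R therefore shows no shift beyond the scatter, unlike the chain change in an 8.6-fold lower number from compound 1 to compound 2 (0.93 log units; beyond the scatter), so this inversion does not match the size of that chain step. One caution applies to this reading: the fact that one of compounds 2 and 4 is drawn with a defined configuration and the other without, at the place where they differ

Within the data shown here, whether the inversion reads the same way on the shorter chain of compound 1 remains open, since the only pair that tests it carries the tetradecyl chain. Also open, going by these compounds, is how the series would respond to a carboxylic acid in place of the amide, or to an amine on the chain end, with either configuration at this ring carbon.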